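The source may report more compounds than this note shows. Statements on the series, on what has been measured and on what is new or still open speak of the compounds shown alone.

Compound 1 `O=C(O)c1cccc(C2=C(c3cc(Br)ccc3OCc3ccc(F)cc3F)CCC2)c1` and compound 2 `O=C(O)c1cccc(C2=C(c3cc(Cl)ccc3OCc3ccccc3)CCC2)c1` share a core that carries a carboxylic acid at one end and a benzyloxy group at the other. In an assay on isolated protein for inhibition of prostaglandin E2 receptor EP1 subtype (Homo sapiens) (a higher number here means a weaker inhibitor, a lower number a stronger inhibitor), compound 1 gives 5.01 nM, and compound 2 gives 5.01 nM, so compound 2 stands level with compound 1, within the scatter. Compound 3 `O=C(O)c1cccc(C2=C(c3cc(Br)ccc3OCc3ccccc3)CCC2)c1` differs from compound 2 by bromo in place of chloro on an aromatic carbon. Among the compounds with values here, no measured pair shows this swap on its own, so nothing beyond the scatter is expected. The step of a 1.0-fold lower number from compound 2 to compound 3 (0.00 log units; within the scatter) is therefore estimated to be small. Compound 3 is expected to give 5 nM, with 2 nM to 12 nM as its range.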

Compound 3, half-maximal inhibitory concentration: 12.6 nM
Compound 3: the middle estimate sits 2.5-fold (0.40 log units) below what was measured; the whole stated range lies below it.
By their numbers in this assay, from the lowest: compounds 1 and 2 (each within the scatter of the next); then compound 3.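

In this assay, bromo in place of chloro, para to a benzyloxy group, is not a neutral swap: the result is a 2.5-fold higher number from compound 2 to compound 3 (0.40 log units; beyond the scatter). With bromo kept, phenyl in place of 2,4-difluorophenyl gives a 2.5-fold higher number from compound 1 to compound 3 (0.40 log units; beyond the scatter), so both ends of the molecule affect the number. Nothing available explains either step.

As far as these compounds go, whether chloro and 2,4-difluorophenyl together would lower the number further remains open. So does how fluoro, methyl or nitrile would behave at the bromo position.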